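The compounds below may be only part of what the source reports. "The series", "measured", "known", "first", "only" and "open" are said of these compounds alone.

Measured compounds: compound 1 `Cc1c(C(=O)NCCCN2CCN(C)CC2)c(-c2cccc(N3CCN(c4ccc(NS(=O)(=O)c5cccc(OC(F)(F)F)c5)cc4)CC3)c2)c(-c2ccc(Cl)cc2)n1C` with 763 nM; compound 2 `Cc1c(C(=O)O)c(-c2cccc(N3CCN(c4ccc(NS(=O)(=O)c5ccc(N[C@H](CCN6CCC(O)CC6)CSc6ccccc6)c(S(=O)(=O)C(F)(F)F)c5)cc4)CC3)c2)c(-c2ccc(Cl)cc2)n1C(C)C` with 4 nM.

In an assay for inhibition of Apoptosis regulator Bcl-2 (Homo sapiens), read by fluorescence polarization, with a stated time of 2 h (a lower number here means a stronger inhibitor, a higher number a weaker inhibitor), compound 1 gives 763 nM, the higher of the two numbers. Compound 2 gives 4 nM, and the gap between the two lies beyond the scatter. Compound 3 `Cc1cccc(S(=O)(=O)Nc2ccc(N3CCN(c4cccc(-c5c(C(=O)NCCCN6CCN(C)CC6)c(C)n(C)c5-c5ccc(Cl)cc5)c4)CC3)cc2)c1` differs from compound 1 by methyl in place of trifluoromethoxy on an aromatic carbon. Within the data shown here, no measured pair shows this change on its own, so the size of the step is not known from the data. The step of a 1.2-fold higher number from compound 1 to compound 3 (0.07 log units; within the scatter) is expected to lie within the scatter. Compound 3 is therefore expected to give 900 nM in this assay, in a range from 300 nM to 3000 nM.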

Compound 3, half-maximal inhibitory concentration: 689 nM
Estimate against measurement, compound 3: 1.3-fold (0.12 log units) above; the range from low to high includes it.
By their numbers in this assay, from the lowest: compound 2; then compounds 3 and 1 (each within the scatter of the next).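

In this assay, methyl in place of trifluoromethoxy on this aromatic carbon, meta to a large group, gives a 1.1-fold lower number from compound 1 to compound 3 (0.04 log units; within the scatter) and so leaves the reading unchanged. Among these compounds, this is the first direct view of this position, and it shows that 3-(trifluoromethoxy)phenyl and 3-methylphenyl cannot be told apart here. No measurement shown explains why the two groups read alike.

On these data alone, whether an amine, a carboxylic acid or a longer chain at this carbon would also read alike remains open. So does whether a bare phenyl ring, with only hydrogen there, would do so.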